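The source may report more compounds than this note shows. Statements on the series, on what has been measured and on what is new or still open speak of the compounds shown alone.

The measured compounds, each with its growth-inhibition value:

Compound 1, `COc1cc(-c2cc(/C=C/C(=O)c3ccc(N)cc3)[nH]n2)cc(OC)c1OC`, gives 1610 nM in a functional assay on ACHN cells (Homo sapiens) for inhibition, read by sulforhodamine B assay, with a stated time of 48 h; a higher number here means a weaker inhibitor of growth, a lower number a stronger inhibitor of growth.
Compound 2, `COc1ccc(-c2cc(/C=C/C(=O)c3ccc(N)cc3)[nH]n2)cc1OC`, gives 1670 nM in this assay.
Compound 3, `COc1cc(C(=O)/C=C/c2cc(-c3cc(OC)c(OC)c(OC)c3)n[nH]2)cc(OC)c1OC`, gives 1620 nM in this assay.

Compound 1 and compound 2 share a core and differ in one place: hydrogen in place of methoxy on an aromatic carbon. That single change produced a 1.0-fold higher number from compound 1 to compound 2 (0.02 log units; within the scatter), so the two values cannot be told apart by this measurement.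

Compound 3 is built on a different core; the difference between the two cores is not broken down here. Its value sits among those of compound 1 and compound 2, and none of the three is separated from the others by more than the usual scatter.

Compound 4, `COc1ccc(-c2cc(/C=C/C(=O)c3cc(OC)c(OC)c(OC)c3)[nH]n2)cc1OC`, is not yet measured. It differs from compound 3 in exactly the way compound 2 differs from compound 1: hydrogen in place of methoxy on an aromatic carbon. The surroundings of the change, as described for both pairs, are the same word for word, so this is the same change on a second core.

Among the measured compounds shown here, the only guide is the earlier pair, where the change left the value essentially unchanged. The expectation for compound 4 therefore rests on compound 3 and on the step from compound 1 to compound 2 being a 1.0-fold higher number from compound 1 to compound 2 (0.02 log units; within the scatter). The step from compound 3 to compound 4 is expected to be a 1.0-fold higher number from compound 3 to compound 4 (0.01 log units; within the scatter) in this assay. Compound 4 is thus estimated at 1650 nM in this assay, most likely between 800 nM and 3400 nM.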

Compound 4, concentration for 50% growth inhibition: 1450 nM
Compound 4: middle estimate off by 1.1-fold (0.06 log units), on the high side; the range from low to high includes it.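

Replacing methoxy with hydrogen on the aromatic ring gave a 1.1-fold lower number from compound 3 to compound 4 (0.05 log units; within the scatter) in this assay, so on this second core, as on the first, the measurement cannot distinguish the two compounds of the pair. Set side by side, the two steps agree as closely as such steps can be expected to: the same change on two cores in this assay, a 1.0-fold higher number (0.02 log units; within the scatter) from compound 1 to compound 2 and a 1.1-fold lower number (0.05 log units; within the scatter) from compound 3 to compound 4, 1.2-fold (0.06 log units) apart, within the scatter of two such steps. This shows that, in these two pairs, the swap carries from one core to the other as a step too small to read, but it is only a comparison of two near-null results, so it does not establish a general rule for the series and cannot show how a change large enough to move the value would transfer between cores.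

The compounds shown carry only methoxy or hydrogen at this place, so it remains open whether a different group there, such as a hydroxyl, a fluorine, a carboxylic acid or a longer chain like ethoxy, would move the value beyond the scatter on either core. On these data alone, it is also open whether the same agreement between cores would hold in cell lines other than the one used here.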